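Adding a Chloro to Compound 2

The source may report more compounds than this note shows. Statements on the series, on what has been measured and on what is new or still open speak of the compounds shown alone.

Compound 1 `Cc1cc(C)cc(Cn2c(SCC(=O)Nc3ccccc3Cl)nc3ccc(Cl)cc32)c1` gives 141000 nM
Compound 2 `Cc1cc(C)cc(Cn2c(SCC(=O)Nc3ccccc3Br)nc3ccccc32)c1` gives >= 143000 nM, which is a limit

In an ADME assay on MT4 cells (Homo sapiens) for cytotoxicity (a lower number here means that less compound is tolerated, a higher number that more compound is tolerated), compound 2 stands at >= 143000 nM. That value is a limit of the assay and not a number, so compound 2 has no exact place in the data.

Compound 3 `Cc1cc(C)cc(Cn2c(SCC(=O)Nc3ccccc3Br)nc3ccc(Cl)cc32)c1` follows from compound 2 by a single change, (chloro in place of hydrogen on an aromatic carbon). Among the compounds with values here, no measured pair shows this change alone, so its size can only be expected. A small step is expected in this assay because compound 1 gives 141000 nM with a chloro on the shared core. The expected at least 1.1-fold lower number from compound 2 to compound 3 (0.04 log units; that floor lies within the scatter) is therefore small. Compound 3 is estimated at 130000 nM. The expected range for compound 3 runs from 65000 nM to 150000 nM, and the assay may again report only a limit.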

Compound 3, half-maximal cytotoxic concentration: 174000 nM
Compound 3: middle estimate off by 1.3-fold (0.13 log units), on the low side; measured number above the stated range.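

In this assay, with a chloro on the shared core, bromo in place of chloro on an aromatic carbon gives a 1.2-fold higher number from compound 1 to compound 3 (0.09 log units; within the scatter), so this exchange does not separate the two compounds in this assay. Compound 2 gives >= 143000 nM, which is a limit of the assay and not a number. The step that adds the chloro, on the aromatic carbon meta to a fused ring and para to a fused ring, therefore cannot be read: the limit of >= 143000 nM in this assay, at which 1 of the 3 values shown sits.

Within the data shown here, whether this chloro shifts the number at all stays open, since only one side of its step is an exact value. Also open, as far as these compounds go, is how an amine or a carboxylic acid on this same aromatic carbon would read in this assay, and how a fluoro or a methoxy group would read in place of the bromo.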